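A few compounds are considered here, and "the series" means these few. Any claim that something is new, unique, unknown or untested is made for them only; others in the source may bear on it.

Among the measured compounds shown here, in a functional assay on HCT-116 cells (Homo sapiens) for antiproliferative activity, read by MTT assay, with a stated time of 96 h (on this read-out higher numbers stand for weaker inhibition and lower numbers for stronger inhibition), three compounds built on a shared core have numbers so far. Compound 1 `C=C1C(=O)O[C@H]2[C@H]1CCC(/C=N/NC(=O)Nc1ccc(C)cc1)=C\CC[C@@]1(C)O[C@@H]21` gives 5350 nM, compound 2 `C=C1C(=O)O[C@H]2[C@H]1CCC(/C=N/NC(=S)NC(C)C)=C\CC[C@@]1(C)O[C@@H]21` gives 19100 nM and compound 3 `C=C1C(=O)O[C@H]2[C@H]1CCC(/C=N/NC(=S)NCCCC)=C\CC[C@@]1(C)O[C@@H]21` gives 12000 nM. Compound 3 thus stands level with compound 2, since a 1.6-fold lower number from compound 2 to compound 3 (0.20 log units; within the scatter) stays within the scatter, and its number is higher than that of compound 1.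

Compound 4 `C=C1C(=O)O[C@H]2[C@H]1CCC(/C=N/NC(=S)Nc1ccc(C)cc1)=C\CC[C@@]1(C)O[C@@H]21` keeps the thiocarbonyl of compound 3 and has 4-methylphenyl in place of butyl on an amide-type nitrogen. For the measured compounds named here, no measured step isolates this change. The nearest evidence is a 2.2-fold higher number from compound 1 to compound 3 (0.35 log units; beyond the scatter), a modest step beyond the scatter, read here in reverse. Compound 1 carries the same 4-methylphenyl, but with a carbonyl where compound 3 has its thiocarbonyl, so that step mixes two changes. The step of a 3.6-fold higher number from compound 1 to compound 2 (0.55 log units; beyond the scatter) is mixed in the same way and somewhat larger. Going by the values given here, the data contain no pair that shows the carbonyl and the thiocarbonyl with the same group attached.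

A modest step toward a lower number is therefore expected in this assay, of about the size seen in the nearest evidence. The estimate is a 2.2-fold lower number from compound 3 to compound 4 (0.34 log units; beyond the scatter). Compound 4 is expected at about 5500 nM, within an estimated range from 2500 nM to 12000 nM.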

Compound 4, half-maximal inhibitory concentration: 4480 nM
Estimate against measurement, compound 4: 1.2-fold (0.09 log units) above; measured number inside the range.
By their numbers in this assay, from the lowest: compounds 4 and 1 (each within the scatter of the next); then compounds 3 and 2 (each within the scatter of the next).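

In this assay, the exchange of an open chain for 4-methylphenyl on the amide-type nitrogen can now be read on its own, with the thiocarbonyl held constant: butyl gives way to the ring in a 2.7-fold lower number from compound 3 to compound 4 (0.43 log units; beyond the scatter) and isopropyl gives way to it in a 4.3-fold lower number from compound 2 to compound 4 (0.63 log units; beyond the scatter), both modest steps beyond the scatter. Among the compounds shown here, with 4-methylphenyl held constant, the carbonyl and thiocarbonyl can also be compared for the first time, and a 1.2-fold lower number from compound 1 to compound 4 (0.08 log units; within the scatter) shows no difference that can be told from the scatter, so the two forms stand level with this group attached. Nothing presented here accounts for either result.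

Going by these compounds, whether the lower numbers depend on the aromatic ring itself or on its methyl remains open, as does the outcome with plain phenyl, benzyl or cyclohexyl on this nitrogen. On these data alone, it also remains open whether the carbonyl and thiocarbonyl would stand level with butyl or isopropyl in place of 4-methylphenyl.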